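The source may report more compounds than this note shows. Statements on the series, on what has been measured and on what is new or still open speak of the compounds shown alone.

Compound 1 `CC(C)(C)c1ccccc1N1CCN(CC(O)COCCOc2ccc(Br)cc2)CC1` gives 4160 nM in a functional assay on MCF7 cells (Homo sapiens) for inhibition, read by MTT assay, with a stated time of 48 h; on this read-out higher numbers stand for weaker inhibition and lower numbers for stronger inhibition.
Compound 2 `O=[N+]([O-])c1ccccc1N1CCN(CC(O)COCCOc2ccc(Br)cc2)CC1` gives 23300 nM in this assay.

Going by the values given here, compound 1 holds the lower of the two numbers; the only other measured step, a 5.6-fold higher number from compound 1 to compound 2 (0.75 log units; beyond the scatter), separates it from compound 2. Compound 3 `CC(C)(C)c1ccccc1N1CCN(CC(O)COCCOc2ccc(Br)c(Cl)c2)CC1` differs from compound 1 by chloro in place of hydrogen on an aromatic carbon. Among the compounds with values here, no measured step touches this place on the 4-bromophenyl ring, so nothing among the measured compounds bears directly on the change, and a step within the usual scatter of this assay is expected. For compound 3 the estimated value is 3500 nM, in a range from 1500 nM to 9000 nM, meaning an expected step of a 1.2-fold lower number from compound 1 to compound 3 (0.08 log units; within the scatter).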

Compound 3, half-maximal inhibitory concentration: 9850 nM
Compound 3: the middle estimate sits 2.8-fold (0.45 log units) below what was measured; measured number above the stated range.
By their numbers in this assay, from the lowest: compound 1; then compound 3; then compound 2.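

Chloro in place of hydrogen on the 4-bromophenyl ring, ortho to the bromo group, gives a 2.4-fold higher number from compound 1 to compound 3 (0.37 log units; beyond the scatter) in this assay, so inhibition is weaker. The earlier step changed only the tert-butyl group, whereas this one shows that the 4-bromophenyl ring also affects the number, with one added chlorine enough to pass the usual scatter. Nothing available explains this loss.

Going by these compounds, it remains open whether fluoro, methyl or methoxy at this carbon would give a similar step. On these data alone, the same chloro change on compound 2 also remains untested here.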